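The source may report more compounds than this note shows. Statements on the series, on what has been measured and on what is new or still open speak of the compounds shown alone.

Three compounds built on one shared core were tested in a functional assay on the whole organism with Rattus norvegicus as the target, read by paw edema, with a stated time of 3 h, at a dose of 100 mg/kg by the oral route; a higher number here means more inhibition at the dose given (going by the name of the read-out), a lower number less inhibition. Compound 1 `Cc1ccc(-c2nc3ccccc3[nH]2)nc1` gives 19%, compound 2 `CCc1ccc(-c2nc3ccccc3[nH]2)nc1` gives 44%, and compound 3 `OCc1ccc(-c2nc3ccccc3[nH]2)nc1` gives -10%, the lowest of the three numbers. Two measured steps end at compound 3 and bear on what follows: a number 29 percentage points lower from compound 1 to compound 3 (beyond the scatter) and a number 54 percentage points lower from compound 2 to compound 3 (beyond the scatter). Compound 4 `CCOC(=O)c1ccc(-c2nc3ccccc3[nH]2)nc1` differs from compound 3 in one place: ethoxycarbonyl in place of hydroxymethyl on an aromatic carbon. For the measured compounds named here, no measured step involves ethoxycarbonyl, so the expectation rests only on the hydroxymethyl compound standing lowest. Because of a number 29 percentage points lower from compound 1 to compound 3 (beyond the scatter) and a number 54 percentage points lower from compound 2 to compound 3 (beyond the scatter), a rise from compound 3 is expected, and compound 4 is expected to show a number 30 percentage points higher from compound 3 to compound 4 (beyond the scatter). Compound 4 is therefore estimated at 20%, with a range from -10% to 50%.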

Compound 4, a percentage reported as inhibition, in the whole organism at one dose (the size of the read-out at that dose, not a potency): -16%
Estimate against measurement, compound 4: 36 percentage points above; measured number below the stated range.
By their numbers in this assay, from the lowest: compounds 4 and 3 (each within the scatter of the next); then compound 1; then compound 2.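

In this assay, ethoxycarbonyl and hydroxymethyl cannot be told apart at this position on the ring, two atoms from the ring nitrogen (a number 6 percentage points lower from compound 3 to compound 4 (within the scatter)), although ethoxycarbonyl is the larger group and has no hydrogen-bond donor. Both oxygen-bearing groups stand apart from the alkyl groups, as ethoxycarbonyl shows against ethyl (a number 60 percentage points lower from compound 2 to compound 4 (beyond the scatter)) and against methyl (a number 35 percentage points lower from compound 1 to compound 4 (beyond the scatter)). No evidence is available that explains this split. On these data alone, whether a propyl chain would extend the rise from methyl to ethyl remains open. So does where a carboxylic acid or an amine would fall.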